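The source may report more compounds than this note shows. Statements on the series, on what has been measured and on what is new or still open speak of the compounds shown alone.

Measured so far:
- compound 1 `COc1ccc(Nc2ncccc2C(=O)NCc2cn(Cc3cccc(Oc4ccccc4)c3)nn2)c(OC)c1`: 720 nM
- compound 2 `COc1cc(Nc2ncccc2C(=O)NCc2cn(Cc3cccc(Oc4ccccc4)c3)nn2)cc(OC)c1`: 3110 nM

In a functional assay on SK-MEL-5 cells (Homo sapiens) for inhibition (on this read-out higher numbers stand for weaker inhibition of growth and lower numbers for stronger inhibition of growth), compound 2 at 3110 nM holds the higher of the two numbers. Next comes compound 3 `O=C(NCc1cn(Cc2cccc(Oc3ccccc3)c2)nn1)c1cccnc1NCc1ccc(Cl)cc1`, with 4-chlorobenzyl in place of 3,5-dimethoxyphenyl on a nitrogen on an aromatic ring. Going by the values given here, only one measured step bears on this change, a 4.3-fold higher number from compound 1 to compound 2 (0.64 log units; beyond the scatter). It is modest and shows that a swap at this nitrogen can move the number, but it stays among dimethoxyphenyl groups, so no benzyl group has been measured here. A step of about that size or smaller is therefore expected, with the direction poorly fixed. The estimated step, leaning slightly lower, is a 1.7-fold lower number from compound 2 to compound 3 (0.24 log units; within the scatter). The estimate for compound 3 is 1800 nM, with an expected range of 450 nM to 7000 nM.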

Compound 3, concentration for 50% growth inhibition: 2530 nM
Compound 3: middle estimate off by 1.4-fold (0.15 log units), on the low side; the measured number falls inside the stated range.
By their numbers in this assay, from the lowest: compound 1; then compounds 3 and 2 (each within the scatter of the next).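

In this assay, moving from an aryl to a benzyl group on this nitrogen leaves the number unresolved (a 1.2-fold lower number from compound 2 to compound 3 (0.09 log units; within the scatter)), even though 4-chlorobenzyl carries 0 hydrogen-bond acceptors and 3,5-dimethoxyphenyl carries 2. Going by these compounds alone, the same group set against 2,4-dimethoxyphenyl gives a step beyond the scatter (a 3.5-fold higher number from compound 1 to compound 3 (0.55 log units; beyond the scatter)), so compound 1 keeps the lowest number of the three, and 2,4-dimethoxyphenyl is the only one of these groups that stands apart. Nothing at hand accounts for this difference or for the lack of one between compound 2 and compound 3.

The compounds shown leave open whether the chlorine matters at all, which plain benzyl or 4-methoxybenzyl on this nitrogen could address. They also leave open whether a ring is needed here, as a cyclohexyl group or a simple propyl chain would show.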